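Swapping the Aryl Group on a Chalcone Sulfonylurea

The source may report more compounds than this note shows. Statements on the series, on what has been measured and on what is new or still open speak of the compounds shown alone.

Measured compounds:
Compound 1, `Cc1ccc(/C=C/C(=O)c2ccccc2NC(=O)NS(=O)(=O)c2ccc(C)cc2)cc1`: 15.3 ug/mL
Compound 2, `Cc1ccc(S(=O)(=O)NC(=O)Nc2ccccc2C(=O)/C=C/c2cccc(O)c2)cc1`: 39.3 ug/mL

In an ADME assay on the whole organism for cytotoxicity, with Artemia salina as the target, with a stated time of 24 h (a higher number here means that more compound is needed for the effect, a lower number that less compound is needed), compound 1 gives 15.3 ug/mL, the lowest of the two numbers; the nearest is compound 2, with 39.3 ug/mL, which is a 2.6-fold higher number from compound 1 to compound 2 (0.41 log units; beyond the scatter) away. The unmeasured compound 3, `Cc1ccc(S(=O)(=O)NC(=O)Nc2ccccc2C(=O)/C=C/c2cccc([N+](=O)[O-])c2)cc1`, differs from compound 1 in one place: 3-nitrophenyl in place of 4-methylphenyl on a double-bonded chain carbon bound to a double-bonded chain carbon. For the measured compounds named here, the only measured step that bears on this is a 2.6-fold higher number from compound 1 to compound 2 (0.41 log units; beyond the scatter), where a group entered at the same place and the number rose modestly. Going by the values given here, no step shows a nitro group directly, so the expectation is that compound 3 will also move upward from compound 1, by about a 1.6-fold higher number from compound 1 to compound 3 (0.21 log units; within the scatter), but with wide uncertainty. In this assay compound 3 is therefore expected to give 25 ug/mL, estimated between 10 ug/mL and 60 ug/mL.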

Compound 3, concentration for half-maximal effect: 44.5 ug/mL
Compound 3: middle estimate off by 1.8-fold (0.25 log units), on the low side; the range from low to high includes it.
By their numbers in this assay, from the lowest: compound 1; then compounds 2 and 3 (each within the scatter of the next).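

In this assay, a second group on the same ring at this place gives a shift of similar kind: 3-nitrophenyl in place of 4-methylphenyl gives a 2.9-fold higher number from compound 1 to compound 3 (0.46 log units; beyond the scatter). Nitro in place of hydroxy on the aromatic carbon gives a 1.1-fold higher number from compound 2 to compound 3 (0.05 log units; within the scatter), so the two groups cannot be told apart in this assay, and the two replacements of 4-methylphenyl shown here both end up above compound 1. Nothing available explains these numbers.

The compounds shown leave open whether the rise follows from losing 4-methylphenyl or from the entry of the new group. As far as these compounds go, it is also open whether a plain phenyl or a 3-aminophenyl at the same place would fall with compound 1 or with the other two.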